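Working notes: cytotoxicity across the shared core

The compounds below may be only part of what the source reports. "The series", "measured", "known", "first", "only" and "open" are said of these compounds alone.

Compound 1 `Cc1ccc(-c2ccc3[nH]c(=O)nc(-c4ccccc4)c3c2)cn1` — > 50000 nM in an ADME assay on L6 cells (Rattus norvegicus) for cytotoxicity, read by fluorescence and resazurin assay, with a stated time of 72 h; on this read-out lower numbers stand for an effect already at smaller amounts and higher numbers for an effect only at larger amounts of compound
Compound 2 `Cc1cncc(-c2ccc3[nH]c(=O)nc(-c4ccccc4)c3c2)c1` — > 50000 nM in this assay

Compound 1 sits at a limit of this assay, not at a number. Compound 2 likewise sits at a limit. The step that the two limits leave unreadable from compound 1 to compound 2 is therefore unreadable, as both values sit at the limit of > 50000 nM in this assay, at which 2 of the 2 values shown sit.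

Compound 3 `O=c1nc(-c2ccccc2)c2cc(-c3ccccc3F)ccc2[nH]1` differs from compound 2 by 2-fluorophenyl in place of 5-methylpyridin-3-yl on an aromatic carbon. Going by the values given here, no measured step in this assay has a readable size, so the expectation rests only on the two limits. Compound 3 is expected at 60000 nM, in the range 20000 nM to 200000 nM, most likely reported again as a limit. The expected step that the limit leaves unreadable from compound 2 to compound 3 is none beyond the scatter.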

Compound 3, half-maximal effective concentration: 55800 nM
Compound 3: the middle estimate sits 1.1-fold (0.03 log units) above what was measured, within the range that was stated.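

Going by these compounds alone, no step to compound 3 can be read from compound 1 or compound 2, because both of those values are limits: the limit of > 50000 nM in this assay, at which 2 of the 3 values shown sit.
Going by these compounds, whether 6-methylpyridin-3-yl, 5-methylpyridin-3-yl and 2-fluorophenyl differ at all in this assay stays open.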